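Removing methylsulfonyl from compound 3: what to expect

The source may hold more compounds than are shown below. What is called first, only, known or untested is meant among the compounds shown, and "the series" means these compounds.

Compound 1 `CCc1ccc(-c2nc3c(c(C)nn3-c3ccccc3)c(-c3ccccc3O)c2C#N)cc1`, compound 2 `CCc1ccc(-c2nc3c(c(C)nn3-c3ccccc3)c(-c3ccccc3[N+](=O)[O-])c2C#N)cc1` and compound 3 `CCc1ccc(-c2nc3c(c(C)nn3-c3ccccc3)c(-c3ccccc3S(C)(=O)=O)c2C#N)cc1` share one core and differ only in a single group on an aromatic carbon. In a physicochemical assay for solubility, read by spectrophotometry, in phosphate buffer, with a stated time of 18 h, at pH 7.4 (a lower number here means a less soluble compound, a higher number a more soluble compound), compound 1 gives 3100 nM, compound 2 gives 1200 nM and compound 3 gives 2200 nM. Compound 3 therefore stands within the scatter of both others, as a 1.4-fold lower number from compound 1 to compound 3 (0.15 log units; within the scatter) and a 1.8-fold higher number from compound 2 to compound 3 (0.26 log units; within the scatter) show. Only a 2.6-fold lower number from compound 1 to compound 2 (0.41 log units; beyond the scatter) goes beyond the scatter.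

Compound 4 `CCc1ccc(-c2nc3c(c(C)nn3-c3ccccc3)c(-c3ccccc3)c2C#N)cc1` carries no group at that place: hydrogen in place of methylsulfonyl on an aromatic carbon, ortho to a large group. The three measured steps bear on this only indirectly. Each swaps one group for another, and none leaves hydrogen there. Their largest size was modest, so a big jump in this assay would be a surprise. Within the data shown here, the direction is a judgement call, with no measured compound lacking a group at that place, and the expectation leans towards a modest step to a lower number. The estimated change is a 2.2-fold lower number from compound 3 to compound 4 (0.34 log units; beyond the scatter). For compound 4 the estimated value is 1000 nM, with an expected range of 350 nM to 2800 nM.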

Compound 4, solubility: 47000 nM
Estimate against measurement, compound 4: 47-fold (1.67 log units) below; measured number above the stated range.
By their numbers in this assay, from the lowest: compounds 2, 3 and 1 (each within the scatter of the next, the first and the last beyond it); then compound 4.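

In this assay, the big divide at this place on the aromatic carbon lies between hydrogen and the three groups, which the swaps among those groups could not show: hydrogen in place of methylsulfonyl gives a 21-fold higher number from compound 3 to compound 4 (1.33 log units; beyond the scatter), hydrogen in place of nitro gives a 39-fold higher number from compound 2 to compound 4 (1.59 log units; beyond the scatter), and hydrogen in place of hydroxy gives a 15-fold higher number from compound 1 to compound 4 (1.18 log units; beyond the scatter). Among these compounds, compound 4 therefore has the highest number of the four, and no compound here goes against this divide, while the only step among the three substituted compounds that lies beyond the scatter, a 2.6-fold lower number from compound 1 to compound 2 (0.41 log units; beyond the scatter), is far smaller than any of these. The compounds shown come with no separate measurement that would explain why removing the group has so large an effect on this number.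

On these data alone, it remains open whether any group at this place keeps the number close to that of compound 4, for example a single fluorine atom or a methyl group, or whether an amine or a carboxylic acid behaves like the three groups here. Also open, as far as these compounds go, is whether removing a group has as large an effect on a different core.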